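Removing a Fluoro Group from Compound 2

The source may report more compounds than this note shows. Statements on the series, on what has been measured and on what is new or still open speak of the compounds shown alone.

Compound 1 `CCOC(=O)c1cc([Se]c2ccccc2)c2cc(Br)ccc2n1` gives 12400 nM
Compound 2 `CCOC(=O)c1cc([Se]c2ccc(F)cc2)c2cc(OC)ccc2n1` gives > 150000 nM (a limit, not a number)
Compound 3 `CCOC(=O)c1cc([Se]c2ccc3cc(OC)ccc3c2)c2cc(OC)ccc2n1` gives 30800 nM

These three compounds were tested in a functional assay on SK-MEL-147 cells (Homo sapiens) for cytotoxicity, read by MTT assay, with a stated time of 24 h (on this read-out higher numbers stand for an effect only at larger amounts of compound and lower numbers for an effect already at smaller amounts), and only two of them returned a true number. Compound 2 is reported as > 150000 nM, which is a limit of this assay and not a number.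

The next compound to be tested is compound 4 `CCOC(=O)c1cc([Se]c2ccccc2)c2cc(OC)ccc2n1`, which puts hydrogen in place of fluoro on an aromatic carbon, para to a large group, so that 4-fluorophenyl becomes phenyl. Among the compounds with values here, the counted difference is hydrogen in place of fluoro on an aromatic carbon and no measured pair of compounds shows this change alone.

A lower number than the limit of compound 2 is expected, though with wide uncertainty. Compound 4 shares its phenyl with compound 1 , which gives 12400 nM in this assay. Against that, compound 4 shares the rest of its structure with compound 2 , so its number may well stay high. The estimated change is an at least 2.5-fold lower number from compound 2 to compound 4 (0.39 log units; beyond the scatter) and it should exceed the scatter. Compound 4 is expected at about 60000 nM in this assay. The estimated range for compound 4 runs from 15000 nM to 150000 nM in this assay.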

Compound 4, half-maximal effective concentration: 33000 nM
Estimate against measurement, compound 4: 1.8-fold (0.26 log units) above; measured number inside the range.
By their numbers in this assay, from the lowest: compound 1; then compounds 3 and 4 (each within the scatter of the next). At a limit, above all of these: compound 2.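

In this assay, within the data shown here, hydrogen in place of fluoro on an aromatic carbon, which turns 4-fluorophenyl into phenyl, gives the first pair of compounds that differ in one place, and the change is a real one: an at least 4.5-fold lower number from compound 2 to compound 4 (0.65 log units; beyond the scatter). From the compounds shown here alone, compound 2 stands at a limit and not at a number, so the true size of this step stays unknown and only its lower bound can be read: the limit of > 150000 nM in this assay, at which 1 of the 4 values shown sits. Compound 4 also forms a second single-change pair, with the phenyl held the same and methoxy in place of bromo on an aromatic carbon, and this change also shifts the result, as shown by a 2.7-fold higher number from compound 1 to compound 4 (0.43 log units; beyond the scatter), so both places on these compounds bear on the number in this cell test.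

The compounds shown leave open whether a chloro or a methyl group on that same aromatic carbon would track with fluoro or with hydrogen. They also leave open whether the fluoro to hydrogen step would be as large with bromo on the core, or with an amine in that place.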